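Moving the Chlorine on a Chlorophenyl Group

A few compounds are considered here, and "the series" means these few. Any claim that something is new, unique, unknown or untested is made for them only; others in the source may bear on it.

Among the compounds with values here, in a functional assay on cells (Homo sapiens) for cytotoxicity, read by MTT assay, with a stated time of 24 h (on this read-out higher numbers stand for weaker inhibition and lower numbers for stronger inhibition), compound 1 `CCCCCCCCCCCCCCNC(=O)[C@H](CO)/N=C/c1ccc(OC)cc1` gives 28100 nM and compound 2 `CCCCCCCCCCCCCCNC(=O)[C@H](CO)/N=C/c1ccccc1Cl` gives 10300 nM, the lower of the two numbers so far. Compound 3 `CCCCCCCCCCCCCCNC(=O)[C@H](CO)/N=C/c1ccc(Cl)cc1` has not yet been measured. It contains the same atoms as compound 2, joined differently: 4-chlorophenyl in place of 2-chlorophenyl on a carbon with a double bond to nitrogen. Within the data shown here, only one measured step bears on this change, and only indirectly. That step, a 2.7-fold lower number from compound 1 to compound 2 (0.44 log units; beyond the scatter), shows a modest move when the group on this carbon is replaced, but it swaps 4-methoxyphenyl for 2-chlorophenyl, not one chlorophenyl for another. Because the change here keeps the chlorine and that step, a 2.7-fold lower number from compound 1 to compound 2 (0.44 log units; beyond the scatter), was modest, a smaller move is expected in this assay, with no clear direction. The expected change is a 1.2-fold higher number from compound 2 to compound 3 (0.07 log units; within the scatter), which would not go beyond the scatter. Compound 3 is estimated at 12000 nM, within a range of 5500 nM to 27000 nM.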

Compound 3, half-maximal inhibitory concentration: 27500 nM
For compound 3 the middle estimate is 2.3-fold (0.36 log units) below the measured one; the whole stated range lies below it.
By their numbers in this assay, from the lowest: compound 2; then compounds 3 and 1 (each within the scatter of the next).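

Moving the chlorine, with no atom added or lost, is enough to shift the result in this assay: 4-chlorophenyl in place of 2-chlorophenyl gives a 2.7-fold higher number from compound 2 to compound 3 (0.43 log units; beyond the scatter), so where the chlorine sits on the ring counts, not merely that it is present. Chloro in place of methoxy on an aromatic carbon gives a 1.0-fold lower number from compound 1 to compound 3 (0.01 log units; within the scatter), which leaves compound 2 as the only one of the three standing apart, with the lowest number. No measurement shown here explains why the two chlorophenyl groups differ.

On these data alone, whether a bromine or a fluorine in place of the chlorine of the 2-chlorophenyl group would keep the lower number remains open. So does whether the same gap between the two chlorophenyl groups would appear with a longer or shorter chain on the amide nitrogen.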